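From Methoxycarbonyl to Propoxycarbonyl on Compound 3

A few compounds are considered here, and "the series" means these few. Any claim that something is new, unique, unknown or untested is made for them only; others in the source may bear on it.

Three compounds have been measured in an assay on membranes from HEK293 cells for displacement of a labelled ligand from adenosine receptor A2b (Homo sapiens), read by scintillation counting, with a stated time of 30 min, tested at 1 uM; on this read-out higher numbers stand for more inhibition at the one concentration tested (going by the name of the read-out) and lower numbers for less inhibition:

compound 1 `CCCOC(=O)C1=C(C)NC(=S)NC1c1ccco1`: 46%
compound 2 `CCCOC(=O)C1=C(C)NC(=S)NC1c1ccoc1`: 45%
compound 3 `COC(=O)C1=C(C)NC(=S)NC1c1ccsc1`: 38%

Compound 3 gives the lowest of the three numbers, but its gaps to compound 2 and to compound 1 both lie within the scatter, so no order among the three can be read from these values. Among the measured compounds shown here, the only measured step between compounds that differ in one place is a number 1 percentage points lower from compound 1 to compound 2 (within the scatter), a change at the ring on the saturated ring carbon that left the read-out essentially unchanged.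

Compound 4 `CCCOC(=O)C1=C(C)NC(=S)NC1c1ccsc1` differs from compound 3 by ethyl in place of hydrogen on a saturated chain carbon bound to an oxygen next to a carbonyl group. Read one bond further out, the same difference is methoxycarbonyl to propoxycarbonyl. For the measured compounds named here, no measured step bears directly on this change: compound 1 and compound 2 already carry the propyl chain, but they also carry a different ring, so their values show only that compounds with the longer chain sit in the same band as compound 3. The expectation for compound 4 in this assay is therefore no step beyond the scatter, estimated as a number 5 percentage points higher from compound 3 to compound 4 (within the scatter). Compound 4 is estimated at 43%, with a range from 30% to 57%.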

Compound 4, a percentage reported as inhibition, at one concentration (the size of the read-out at that concentration, not a potency): 26%
For compound 4 the middle estimate is 17 percentage points above the measured one; the whole stated range lies above it.
By their numbers in this assay, from the lowest: compound 4; then compounds 3, 2 and 1 (each within the scatter of the next).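

In this assay, among the compounds shown here, the change from methoxycarbonyl to propoxycarbonyl with thiophen-3-yl held fixed gives a number 12 percentage points lower from compound 3 to compound 4 (beyond the scatter) and so shows for the first time that the read-out responds to ethyl in place of hydrogen at this place. With propoxycarbonyl held fixed, the ring on the saturated ring carbon also counts: thiophen-3-yl gives a number 19 percentage points lower from compound 2 to compound 4 (beyond the scatter) against furan-3-yl and a number 20 percentage points lower from compound 1 to compound 4 (beyond the scatter) against furan-2-yl, although the two furan compounds lie within the scatter of each other. The propyl chain therefore does not set the read-out on its own, since its number differs with the ring it is paired with, and no evidence is available to explain either kind of step.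

As far as these compounds go, whether methoxycarbonyl to propoxycarbonyl brings a similar step when the ring is furan-2-yl or furan-3-yl stays open. Also open, from the compounds shown here alone, is how the read-out would run with an ethyl or butyl chain, or with a carboxylic acid or an amide, at this place, and whether a phenyl ring on the saturated ring carbon would sit with the furan compounds or with compound 4.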